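The source may report more compounds than this note shows. Statements on the series, on what has been measured and on what is new or still open speak of the compounds shown alone.

In an ADME assay on HepG2 2.2.15 cells (Homo sapiens) for cytotoxicity, read by MTT assay, with stated times of 48 h and 9 days (on this read-out lower numbers stand for higher toxicity in this test and higher numbers for lower toxicity in this test), compound 3 `O=C(/C=C/c1coc2cc(O)ccc2c1=O)NCc1ccccc1` gives 436000 nM, the lowest of the three numbers measured. Compound 1 `COc1ccc2c(=O)c(/C=C/C(=O)Nc3ccc(C)cc3)coc2c1` gives 979000 nM and compound 2 `COc1ccc2c(=O)c(/C=C/C(=O)Nc3cc(C)ccc3C)coc2c1` gives 1100000 nM; the one shown step, a 1.1-fold higher number from compound 1 to compound 2 (0.05 log units; within the scatter), lies within the scatter. Compound 4 `COc1ccc2c(=O)c(/C=C/C(=O)NCc3ccccc3)coc2c1` differs from compound 3 by methyl in place of hydrogen on an oxygen on an aromatic ring. For the measured compounds named here, no measured step covers this hydroxy-to-methoxy change; compounds 1 and 2 also carry a methoxy but differ from compound 3 in a second place, so their higher numbers only hint at the direction. Compound 4 is therefore expected to lie somewhat higher, with a step of a 1.7-fold higher number from compound 3 to compound 4 (0.24 log units; within the scatter) near the edge of the scatter. The value of compound 4 is estimated at 750000 nM, in the range 320000 nM to 1700000 nM.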

Compound 4, half-maximal cytotoxic concentration: 376000 nM
Compound 4: the middle estimate sits 2.0-fold (0.30 log units) above what was measured; measured number inside the range.
By their numbers in this assay, from the lowest: compounds 4 and 3 (each within the scatter of the next); then compounds 1 and 2 (each within the scatter of the next).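

In this assay methyl in place of hydrogen on the oxygen gives a 1.2-fold lower number from compound 3 to compound 4 (0.06 log units; within the scatter) and so no readable change while benzyl sits on the amide-type nitrogen. Among the methoxy compounds, benzyl in place of 4-methylphenyl gives a 2.6-fold lower number from compound 1 to compound 4 (0.42 log units; beyond the scatter) and benzyl in place of 2,5-dimethylphenyl gives a 2.9-fold lower number from compound 2 to compound 4 (0.47 log units; beyond the scatter) and thus a modest difference tied to the group on that nitrogen. Nothing at hand explains either result. On these data alone, whether a longer chain on this oxygen, such as ethoxy or butoxy, would shift the number remains open. So does the effect of an amine or a carboxylic acid on the benzyl group.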